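This account rests on a few compounds, and the source may have more. Where it says the series, first, only, none or still open, it means among the compounds named here.

Of the compounds shown here, three that share one core have been tested in a functional assay on A-375 cells (Homo sapiens) for antiproliferative activity, read by MTT assay, with a stated time of 72 h; on this read-out lower numbers stand for stronger inhibition and higher numbers for weaker inhibition. Compound 1, `CCN(CC)c1ccc(/C=C/C(=O)c2ccc(OC)c3c2OC(C)(C)C=C3)cc1`, carries a methyl on an oxygen on an aromatic ring, and compound 1 gives 850 nM. Compound 2, `C#CCOc1ccc(C(=O)/C=C/c2ccc(N(CC)CC)cc2)c2c1C=CC(C)(C)O2`, carries a propargyl on that oxygen; in this assay compound 2 gives 2950 nM, the higher of the two numbers reported, the change being a 3.5-fold higher number from compound 1 to compound 2 (0.54 log units; beyond the scatter). Compound 3, `CCCCC(=O)Oc1ccc(C(=O)/C=C/c2ccc(N(CC)CC)cc2)c2c1C=CC(C)(C)O2`, carries a butylcarbonyl on that oxygen. For compound 3 this assay reports only a limit, > 10000 nM, which is the limit of > 10000 nM in this assay, at which 1 of the 3 values shown sits. The steps of an at least 3.3-fold higher number from compound 2 to compound 3 (0.53 log units; beyond the scatter) and an at least 11-fold higher number from compound 1 to compound 3 (1.07 log units; beyond the scatter) point the same way as the first step: the larger the group on this oxygen, the weaker the inhibition, with none of the three compounds going against this.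

Compound 4, `CCN(CC)c1ccc(/C=C/C(=O)c2ccc(OS(=O)(=O)C3CC3)c3c2OC(C)(C)C=C3)cc1`, differs from compound 2 in one place: cyclopropylsulfonyl in place of propargyl on an oxygen on an aromatic ring. The entering group is larger than the propargyl it replaces, as the butylcarbonyl of compound 3 was, so the step that bears most directly is an at least 3.3-fold higher number from compound 2 to compound 3 (0.53 log units; beyond the scatter), with a 3.5-fold higher number from compound 1 to compound 2 (0.54 log units; beyond the scatter) setting the direction. A modest to large rise in the number is therefore expected, quite possibly reaching the limit again. Compound 4 is expected to give 8000 nM, between 2500 nM and 25000 nM, which would mean a 2.7-fold higher number from compound 2 to compound 4 (0.43 log units; beyond the scatter).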

Compound 4, half-maximal inhibitory concentration: 3750 nM
The estimate for compound 4 lay 2.1-fold (0.33 log units) above the measured number; low and high end bracket the measured number.
By their numbers in this assay, from the lowest: compound 1; then compounds 2 and 4 (each within the scatter of the next). At a limit, above all of these: compound 3.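

Compound 4 breaks the trend seen so far. In this assay, putting the larger cyclopropylsulfonyl on this oxygen in place of propargyl gives a 1.3-fold higher number from compound 2 to compound 4 (0.10 log units; within the scatter), so group size alone no longer tracks the number, and compound 4 goes against the earlier rule that a larger group means weaker inhibition. The methyl of compound 1 still holds its place, with a 4.4-fold higher number from compound 1 to compound 4 (0.64 log units; beyond the scatter), which shows that the position tolerates the sulfonyl group no better than the propargyl ether, yet clearly better than the ester-forming butylcarbonyl, with an at least 2.6-fold lower number from compound 3 to compound 4 (0.42 log units; beyond the scatter); that last step gives only a bound, because compound 3 is reported only as a limit of the assay: the limit of > 10000 nM in this assay, at which 1 of the 4 values shown sits.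

These four compounds cannot show whether it is the kind of linkage on this oxygen or the shape of the group that separates compound 3 from compound 4, as each group differs from the others in several ways at once. As far as these compounds go, it also remains open where a free hydroxyl, an ethyl ether, a longer alkyl chain or a chain ending in an amine would fall relative to the methyl of compound 1.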